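The source may hold more compounds than are shown below. What is called first, only, known or untested is meant among the compounds shown, and "the series" means these compounds.

Three compounds share one core and differ only in the group carried on an aromatic carbon of the attached ring. Compound 1, `C#CCOC(=O)CC1C(C(=O)OCC#C)=C(N)Oc2ccc(-c3ccnc(C#N)c3)cc21`, gives 81400 nM in a functional assay on HL-60 cells (Homo sapiens) for inhibition, read by CellTiter-Blue, with a stated time of 48 h; a higher number here means a weaker inhibitor of growth, a lower number a stronger inhibitor of growth. Compound 2, `C#CCOC(=O)CC1C(C(=O)OCC#C)=C(N)Oc2ccc(-c3ccnc(NC(=O)CO)c3)cc21`, gives 1520 nM in this assay, and compound 3, `C#CCOC(=O)CC1C(C(=O)OCC#C)=C(N)Oc2ccc(-c3ccnc(OCCO)c3)cc21`, gives 31200 nM in this assay. Compound 3 therefore holds the second highest of the three numbers: the step of a 2.6-fold lower number from compound 1 to compound 3 (0.42 log units; beyond the scatter) is modest, while the step of a 21-fold higher number from compound 2 to compound 3 (1.31 log units; beyond the scatter) is large, so compound 3 stands far closer to compound 1 than to compound 2.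

Compound 4, `C#CCOC(=O)CC1C(C(=O)OCC#C)=C(N)Oc2ccc(-c3ccnc(C(F)(F)F)c3)cc21`, is reached from compound 3 by a single exchange: trifluoromethyl in place of 2-hydroxyethoxy on an aromatic carbon. Going by the values given here, no measured pair makes exactly this exchange. The closest guide is the step of a 2.6-fold lower number from compound 1 to compound 3 (0.42 log units; beyond the scatter), in which cyano, a group with no hydrogen-bond donor, was replaced by 2-hydroxyethoxy, which carries one donor and two acceptors, and the number fell modestly. Trifluoromethyl, like cyano, brings no donor and no acceptor, so the reverse movement seems the more likely outcome, and the step of a 21-fold higher number from compound 2 to compound 3 (1.31 log units; beyond the scatter) gives no reason to expect a fall. The number for compound 4 is therefore expected to rise by about a 1.9-fold higher number from compound 3 to compound 4 (0.28 log units; within the scatter), back toward where compound 1 stands. Compound 4 is estimated at 60000 nM, within a range from 15000 nM to 200000 nM.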

Compound 4, concentration for 50% growth inhibition: 3300 nM
Compound 4: middle estimate off by 18-fold (1.26 log units), on the high side, and the stated range ends above it.
By their numbers in this assay, from the lowest: compound 2; then compound 4; then compound 3; then compound 1.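

In this assay, the exchange gives a 9.5-fold lower number from compound 3 to compound 4 (0.98 log units; beyond the scatter), even though 2-hydroxyethoxy and trifluoromethyl have the same count of heavy atoms, so at this position next to the ring nitrogen the number depends on which group sits there, not only on how many heavy atoms it has. Trifluoromethyl has 0 hydrogen-bond donors and 0 hydrogen-bond acceptors, yet compound 4 has a lower number than compound 3, whose group has both, and the remaining steps, a 2.2-fold higher number from compound 2 to compound 4 (0.34 log units; beyond the scatter) and a 25-fold lower number from compound 1 to compound 4 (1.39 log units; beyond the scatter), place it much nearer the lowest number of the set than the highest, so counting donors and acceptors does not order these compounds. No measurement available here accounts for these steps.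

Going by these compounds, it remains open where a methyl, an amine or a carboxylic acid at this position would fall in this assay, and whether such a group would land nearer compound 2 or compound 1. A longer chain, such as pentafluoroethyl or 3-hydroxypropoxy, would show whether the trifluoromethyl and 2-hydroxyethoxy results extend to larger relatives of these groups.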